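Shortening the Ester Chain of an Adenine Lactate Series

The compounds below may be only part of what the source reports. "The series", "measured", "known", "first", "only" and "open" are said of these compounds alone.

Three esters built on one shared core have been examined in a functional assay on PRK cells (Oryctolagus cuniculus) for cytotoxicity; on this read-out lower numbers stand for higher toxicity in this test and higher numbers for lower toxicity in this test. Compound 1 `COCCOC(=O)C(O)Cn1cnc2c(N)ncnc21` carries the 2-methoxyethyl ester; in this assay compound 1 reaches only the limit of > 400 ug/mL. Compound 3 `CCC(C)OC(=O)C(O)Cn1cnc2c(N)ncnc21`, the sec-butyl ester, likewise gives only the limit of > 400 ug/mL. Going by the values given here, compound 2 `CC(C)CCOC(=O)C(O)Cn1cnc2c(N)ncnc21`, the isopentyl ester, is the single member with a number: in this assay compound 2 gives 400 ug/mL, so compound 2 stands as the only value that is not a limit, the other two sitting at the limit of > 400 ug/mL in this assay, at which 2 of the 3 values shown sit. The step of a number no higher from compound 1 to compound 2 (the limit leaves the size open) and the step of a number no lower from compound 2 to compound 3 (the limit leaves the size open) therefore cannot be sized, and the step that the two limits leave unreadable from compound 1 to compound 3 runs between two limits.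

Compound 4 `CC(C)OC(=O)C(O)Cn1cnc2c(N)ncnc21` differs from compound 2 in one place: isopropyl in place of isopentyl on an oxygen next to a carbonyl group. The measured step that bears on this is a number no lower from compound 2 to compound 3 (the limit leaves the size open), which also put a smaller alkyl on the same oxygen and came out no lower. No step beyond the usual scatter is therefore expected in this assay, and a result that is itself a limit would fit. For compound 4 the expected value in this assay is 400 ug/mL, within 200 ug/mL to 800 ug/mL. The step of no change at the digits printed from compound 2 to compound 4 (within the scatter) is thus expected to be flat.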

Compound 4, minimum cytotoxic concentration: > 400 ug/mL
Compound 4 ended at the assay's limit; the forecaster's own chance of this, stated with the estimate: 60%; the middle value sits exactly at the limit.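

In this assay, isopropyl in place of isopentyl on an oxygen next to a carbonyl group gives a number no lower from compound 2 to compound 4 (the limit leaves the size open), so isopropyl now joins sec-butyl as a second alkyl ester at this position that leaves the read-out no lower than the isopentyl ester does. Compound 4 gives > 400 ug/mL, which is a limit of the assay. The steps to compound 4 from compound 1 and from compound 3 cannot be read, and compound 2 stays the only ester with a number, the others sitting at one limit: the limit of > 400 ug/mL in this assay, at which 3 of the 4 values shown sit.

Going by these compounds, the true values of compound 1, compound 3 and compound 4 stay open, so no order among them can be given. On these data alone, it also stays open whether a longer chain than isopentyl on this oxygen, or a carboxylic acid in place of the ester, would bring the read-out in this assay to a number clearly lower than that of compound 2.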